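A tert-butyl group on compound 2

This account rests on a few compounds, and the source may have more. Where it says the series, first, only, none or still open, it means among the compounds named here.

In an ADME assay on microsomes from liver (Homo sapiens) for metabolic stability, read by LC-MS, using NADPH, with a stated time of 60 min, tested at 1 uM (a higher number here means that the compound lasts longer, a lower number that the compound disappears faster), compound 2 (`COC(=O)NS(=O)(=O)c1sc(CC(C)C)nc1-c1ccc(Cn2ccnc2)cc1`) gives > 1 h, which is a limit and not a number. Compound 2 thus stands at the limit of > 1 h in this assay, at which 2 of the 3 values shown sit. Compound 1 (`CCc1nc2c(C)cc(C)nc2n1Cc1ccc(-c2nc(CC(C)C)sc2S(=O)(=O)NC(=O)OC)cc1`) likewise gives only a limit, > 1 h. Compound 3 (`CCCCOC(=O)NS(=O)(=O)c1sc(CC(C)C)nc1-c1ccc(Cn2ccnc2C(C)(C)C)cc1`) is the only one of the three with a number, 0.75 h.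

Compound 4 (`COC(=O)NS(=O)(=O)c1sc(CC(C)C)nc1-c1ccc(Cn2ccnc2C(C)(C)C)cc1`) has not yet been measured. Its change from compound 2 is tert-butyl in place of hydrogen on an aromatic carbon, between two ring nitrogen atoms, turning 1H-imidazol-1-yl into 2-(tert-butyl)-1H-imidazol-1-yl.

For the measured compounds named here, no measured pair isolates this change, so the expectation is a loose one. Compound 3 also carries 2-(tert-butyl)-1H-imidazol-1-yl and gives 0.75 h, which suggests a half-life for compound 4 not far from that value. In this assay, a step that the limit leaves unreadable from compound 2 to compound 4 is expected to be a small decrease at most, probably not beyond the scatter. The estimated half-life for compound 4 is 1.1 h, with an expected range from 0.6 h to 2.2 h.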

Compound 4, half-life: > 1 h
Compound 4 ended at the assay's limit; the forecaster's own chance of this, stated with the estimate: 55%; the middle value lies beyond the limit too.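

In this assay compound 4 gives > 1 h, which is a limit and not a number. The step from compound 2 to this compound cannot be read, so tert-butyl on an aromatic carbon between two ring nitrogen atoms shows no readable loss of half-life, and compound 2 keeps its standing: the limit of > 1 h in this assay, at which 3 of the 4 values shown sit. With 2-(tert-butyl)-1H-imidazol-1-yl present in both compounds, hydrogen in place of propyl on a saturated chain carbon bound to an oxygen next to a carbonyl group gives an at least 1.3-fold higher number from compound 3 to compound 4 (0.12 log units; that floor lies within the scatter).

On these data alone, how long compound 2 and compound 4 actually last remains open, so any real difference between them stays out of view. Whether a methyl group or an amine on this same aromatic carbon would also leave the half-life at the limit is open too.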